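A few compounds are considered here, and "the series" means these few. Any claim that something is new, unique, unknown or untested is made for them only; others in the source may bear on it.

Compound 1 `CC(=O)c1cc(C(=O)N[C@@H](C)Cn2ccc(-c3cc(F)c(C#N)c(Cl)c3)n2)n[nH]1`: > 30000 nM, a limit
Compound 2 `C[C@@H](Cn1ccc(-c2ccc(C#N)c(Cl)c2)n1)NC(=O)c1cccc(OCC(O)CO)c1`: > 30000 nM, a limit
Compound 3 `C[C@@H](Cn1ccc(-c2ccc(C#N)c(Cl)c2)n1)NC(=O)C1CC(=O)C1`: "not determined" (no result reported)

In a functional assay on CWR22R cells (Homo sapiens) for antiproliferative activity, read by CCK-8 assay, with a stated time of 6 days (on this read-out higher numbers stand for weaker inhibition and lower numbers for stronger inhibition), compound 3 gives "not determined" (no result reported), so it has no number of its own. The other readings are both limits: the limit of > 30000 nM in this assay, at which 2 of the 3 values shown sit. Compound 4 `C[C@@H](Cn1ccc(-c2ccc(C#N)c(Cl)c2)n1)Nc1nccc(Cl)n1` carries 4-chloropyrimidin-2-yl in place of (3-oxocyclobutyl)carbonyl on an amine nitrogen. Within the data shown here, no measured step is available to size this change, and compound 3 offers no number to start from. In this assay the expectation is therefore for no clear move away from the weak end of the scale, which compound 1 marks with its limit of > 30000 nM. Compound 4 is estimated at 15000 nM, with an expected range of 4000 nM to 30000 nM.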

Compound 4, half-maximal inhibitory concentration: > 30000 nM
Compound 4 was reported as a limit; the forecaster's own chance of this, stated with the estimate: 50%; middle value at least 2.0-fold (0.30 log units) from the limit.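

In this assay compound 4 gives > 30000 nM, which is a limit, and compound 3 has no number, so no step can be read between them. The compounds shown leave open what effect 4-chloropyrimidin-2-yl has in place of (3-oxocyclobutyl)carbonyl.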